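Benzamide in place of the diaryl urea: compound 3

The source may hold more compounds than are shown below. What is called first, only, known or untested is meant among the compounds shown, and "the series" means these compounds.

compound 1 `COc1cc(-c2nn(-c3cccc(NC(=O)Nc4ccc(Cl)c(Cl)c4)c3)cc2-c2ccncc2)ccc1Cl`: 34200 nM
compound 2 `COc1cc(-c2nn(-c3cccc(NC(=O)Nc4ccc(Cl)c(C(F)(F)F)c4)c3)cc2-c2ccncc2)ccc1Cl`: > 32500 nM

In a functional assay on DU-145 cells (Homo sapiens) for inhibition, read by sulforhodamine B assay, with a stated time of 48 h (on this read-out lower numbers stand for stronger inhibition of growth and higher numbers for weaker inhibition of growth), compound 1 gives 34200 nM. For compound 2 only a limit is known: in this assay compound 2 gives > 32500 nM, which is a limit of the assay and not a number (the limit of > 32500 nM in this assay, at which 1 of the 2 values shown sits). Within the data shown here, the only measured step, a step that the limit leaves unreadable from compound 1 to compound 2, therefore cannot be read in size. Compound 3 `COc1cc(-c2nn(-c3cccc(NC(=O)c4ccccc4)c3)cc2-c2ccncc2)ccc1Cl` is the next member; it differs from compound 2 by phenyl in place of (4-chloro-3-(trifluoromethyl)phenyl)amino on a carbonyl carbon, so the shared core is kept and only the group on the carbonyl carbon changes. Among the measured compounds shown here, no measured step touches that carbon, and the one step on record is unreadable, so the change from compound 2 to compound 3 has no precedent in the numbers. Both measured compounds show weak inhibition of growth, which leaves any estimate broad. The step of an at least 1.0-fold lower number from compound 2 to compound 3 (0.03 log units; that floor lies within the scatter) is expected to stay within the usual scatter. Compound 3 is estimated at 30000 nM, between 8000 nM and 100000 nM, with a fair chance that only a limit is reported.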

Compound 3, concentration for total growth inhibition: 54700 nM
Estimate against measurement, compound 3: 1.8-fold (0.26 log units) below, and the stated range covers the measured number.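

In this assay, phenyl in place of (3,4-dichlorophenyl)amino on the carbonyl carbon gives a 1.6-fold higher number from compound 1 to compound 3 (0.20 log units; within the scatter). Among these compounds, this is the first readable step, and it shows that the benzamide of compound 3 and the diaryl urea of compound 1 are not told apart at this position, even though the whole aryl amino group is exchanged for a bare phenyl. The step from compound 2 to compound 3 cannot be read, and compound 2 carries only a limit of the assay, not a number: the limit of > 32500 nM in this assay, at which 1 of the 3 values shown sits.

Still open, going by these compounds, is whether any group on this carbonyl carbon can give a number beyond the scatter from compound 1 and compound 3, for instance a saturated amine such as morpholine, or a phenyl carrying a carboxylic acid. Also open is whether the lack of a separation between the urea and the benzamide holds when the rest of the shared core is changed, as every compound shown keeps that core unaltered and each sits at weak inhibition of growth.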